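A Flat Series and One Untested Change on Nitrogen

The compounds below may be only part of what the source reports. "The series", "measured", "known", "first", "only" and "open" are said of these compounds alone.

Of the compounds shown here, three sharing one core have been measured in a functional assay on K562 cells (Homo sapiens) for cytotoxicity, read by sulforhodamine B assay; on this read-out higher numbers stand for weaker inhibition of growth and lower numbers for stronger inhibition of growth. Compound 1 `COc1ccc(/C=N\NC(=S)NC(C)(C)CCC[C@](C)(O)[C@@H]2CC=C(C)CC2)cc1` gives 34900 nM. Compound 2 `CC1=CC[C@@H]([C@@](C)(O)CCCC(C)(C)NC(=S)N/N=C\c2ccc(O)cc2)CC1` gives 31100 nM, and compound 3 `CC1=CC[C@@H]([C@@](C)(O)CCCC(C)(C)NC(=S)N/N=C\c2ccc(N(C)C)cc2)CC1` gives 42000 nM. Compound 2 therefore stands level with the other two, since all three numbers lie within the scatter of one another. The measured steps are a 1.1-fold lower number from compound 1 to compound 2 (0.05 log units; within the scatter), a 1.2-fold higher number from compound 1 to compound 3 (0.08 log units; within the scatter) and a 1.4-fold higher number from compound 2 to compound 3 (0.13 log units; within the scatter), and each exchanges only hydroxy, methoxy or dimethylamino on the aromatic ring.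

Compound 4 `CC1=CC[C@@H]([C@@](C)(O)CCCC(C)(C)NC(=S)N/N=C(/C)c2ccccc2)CC1` has not yet been measured. The change leading to it is a group of 9 heavy atoms (8 carbon, 1 nitrogen; one six-membered aromatic ring of carbon only) in place of a group of 9 heavy atoms (7 carbon, 1 nitrogen, 1 oxygen; one six-membered aromatic ring of carbon only), on an amide-type nitrogen. This replaces more of the structure than any of the three measured steps, and none of them tests it directly, so they serve only as an indirect guide. What they show is a series that has stayed flat so far, with even the largest gap, a 1.4-fold higher number from compound 2 to compound 3 (0.13 log units; within the scatter), remaining within the scatter. In this assay the expected result is therefore no shift beyond the scatter, with an estimated step of a 1.1-fold higher number from compound 2 to compound 4 (0.05 log units; within the scatter). Compound 4 is estimated at 35000 nM, with an expected range from 18000 nM to 65000 nM.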

Compound 4, concentration for total growth inhibition: 70 nM
Compound 4: middle estimate off by 500-fold (2.70 log units), on the high side; the whole stated range lies above it.
By their numbers in this assay, from the lowest: compound 4; then compounds 2, 1 and 3 (each within the scatter of the next).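

The group on the amide-type nitrogen whose other neighbour is the thiocarbonyl carbon turns out to be far from silent in this assay, with a change of a 440-fold lower number from compound 2 to compound 4 (2.65 log units; beyond the scatter) and one of a 500-fold lower number from compound 1 to compound 4 (2.70 log units; beyond the scatter). Exchanging hydroxy, methoxy and dimethylamino on the aromatic ring had left compounds 1, 2 and 3 within the scatter of one another, so the flatness of those three compounds held only for those exchanges and did not extend to replacing the group as a whole, which here brings in 8 carbon and 1 nitrogen with 0 hydrogen-bond donors. The compounds shown carry no information on why this replacement has so large an effect.

The group changes as a whole from compound 2 to compound 4, so the compounds shown do not separate the loss of the oxygen-bearing substituent from the gain of a carbon, and neither change is seen alone. Going by these compounds, how an ethyl or cyclopropyl group in the entering group, or a fluorine on its aromatic ring, would read in this assay also remains open.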